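The source may hold more compounds than are shown below. What is called first, only, known or untested is meant among the compounds shown, and "the series" means these compounds.

compound 1 `C=CC(=O)N1C(=O)CC(c2ccc(OC)cc2)Sc2ccccc21` gives 92100 nM
compound 2 `C=CC(=O)N1C(=O)CCSc2ccccc21` gives 44800 nM
compound 3 `C=CC(=O)N1C(=O)CC(c2ccccc2Cl)Sc2ccccc21` gives 91400 nM

These values come from a functional assay on HL-60 cells (Homo sapiens) for cytotoxicity, read by CCK-8 assay, with a stated time of 24 h; on this read-out higher numbers stand for weaker inhibition and lower numbers for stronger inhibition. Compound 1 and compound 3 lie within the scatter of each other at the upper end of the three numbers, and compound 2 lies lower.

The next compound is compound 4 `C=CC(=O)N1C(=O)CC(c2ccc(-c3ccccc3)cc2)Sc2ccccc21`, and the change is phenyl in place of methoxy on an aromatic carbon (phenyl in place of methoxy on an aromatic carbon, para to a large group). Within the data shown here, no measured step alters the methoxy group alone. The nearest evidence comes from changes to the whole aryl group. The swap to 2-chlorophenyl gives a 1.0-fold lower number from compound 1 to compound 3 (0.00 log units; within the scatter), while removing the aryl group gives the modest 2.1-fold lower number from compound 1 to compound 2 (0.31 log units; beyond the scatter), and restoring an aryl group gives the equally modest a 2.0-fold higher number from compound 2 to compound 3 (0.31 log units; beyond the scatter). Three compounds are thin ground, but on this evidence no step beyond the scatter is expected in this assay. The estimated step is a 1.3-fold lower number from compound 1 to compound 4 (0.12 log units; within the scatter). For compound 4 the expected value is 70000 nM, with an estimated range of 25000 nM to 150000 nM.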

Compound 4, half-maximal inhibitory concentration: 118000 nM
The estimate for compound 4 lay 1.7-fold (0.23 log units) below the measured number, within the range that was stated.
By their numbers in this assay, from the lowest: compound 2; then compounds 3, 1 and 4 (each within the scatter of the next).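

Phenyl in place of methoxy on an aromatic carbon, para to a large group, is the first change in the series confined to this position, and in this assay it gives a 1.3-fold higher number from compound 1 to compound 4 (0.11 log units; within the scatter), a step within the scatter. Methoxy and phenyl therefore cannot be told apart here, even though the entering group brings 6 heavy atoms and a six-membered aromatic ring of carbon only, where the leaving group has 2 heavy atoms and no ring. Nothing measured for these compounds accounts for this result.

From the compounds shown here alone, both groups at this position lack hydrogen-bond donors and a net charge, so it remains open whether an amine or a carboxylic acid on the same aromatic carbon would shift the number beyond the scatter. A smaller substituent such as fluorine, or a longer chain, is equally untested by the compounds shown here.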